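The source may hold more compounds than are shown below. What is called first, only, known or untested is meant among the compounds shown, and "the series" means these compounds.

Measured compounds: compound 1 `Cc1c(O)ccc2c1[C@H](Cn1cc(-c3ccc(C(F)(F)F)cc3)nn1)[C@@]13CC(=O)[C@@](C)(CC[C@@H]21)C3`, compound 2 `Cc1ccc(-c2cn(C[C@H]3c4c(ccc(O)c4C)[C@@H]4CC[C@@]5(C)C[C@]43CC5=O)nn2)cc1`, compound 3 `Cc1ccc(-c2cn(C[C@H]3c4c(ccc(OS(=O)(=O)c5ccc(C)cc5)c4C)[C@@H]4CC[C@@]5(C)C[C@]43CC5=O)nn2)cc1`.

In a functional assay on MCF7 cells (Homo sapiens) for cytotoxicity, read by MTT assay, with a stated time of 4 days (a higher number here means a weaker inhibitor, a lower number a stronger inhibitor), compound 1 gives only a limit, > 20000 nM. In this assay compound 2 also gives only a limit, > 20000 nM. Compound 3 likewise returns only a limit in this assay, > 20000 nM. The step that the two limits leave unreadable from compound 2 to compound 1 therefore cannot be sized; the change is trifluoromethyl in place of methyl on an aromatic carbon. The step that the two limits leave unreadable from compound 2 to compound 3 is equally unreadable, and its change, ((4-methylphenyl)sulfonyl in place of hydrogen on an oxygen on an aromatic ring), is also how the core of compound 3 differs from the core of compound 2. Compound 4 `Cc1ccc(S(=O)(=O)Oc2ccc3c(c2C)[C@H](Cn2cc(-c4ccc(C(F)(F)F)cc4)nn2)[C@@]24CC(=O)[C@@](C)(CC[C@@H]32)C4)cc1` carries the same change as compound 1 relative to compound 2, here applied to compound 3: trifluoromethyl in place of methyl on an aromatic carbon. Because the limit of > 20000 nM in this assay, at which 3 of the 3 values shown sit, holds for every value shown, compound 4 is expected to show a step that the limit leaves unreadable from compound 3 to compound 4, most likely another limit. The estimate for compound 4 is 25000 nM.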

Compound 4, half-maximal inhibitory concentration: > 20000 nM
Compound 4: no number, only a limit; the forecaster's own chance of this, stated with the estimate: 85%; the middle value is on the limit's open side.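

Compound 4 gives only a limit in this assay, and neither its step from compound 3 nor its step from compound 1 can be read. The compounds shown leave open whether trifluoromethyl in place of methyl, or (4-methylphenyl)sulfonyl in place of hydrogen, changes the result in this assay at all.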